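The compounds below may be only part of what the source reports. "The series", "measured", "known", "first", "only" and "open" are said of these compounds alone.

Compound 1 `CCCS(=O)(=O)Nc1ccc(F)c(C(=O)c2n[nH]c3ncc(-c4ccccc4OC)cc23)c1F`: 1.9%
Compound 2 `CCCS(=O)(=O)Nc1ccc(F)c(C(=O)c2n[nH]c3ncc(-c4ccccc4O)cc23)c1F`: 9%
Compound 3 `CCCS(=O)(=O)Nc1ccc(F)c(C(=O)c2n[nH]c3ncc(-c4cccc(O)c4)cc23)c1F`: 2.2%

In an assay for binding affinity to dual specificity mitogen-activated protein kinase kinase 4 (Homo sapiens), read by KINOMEscan, tested at 100 nM (a higher number here means a weaker effect of the compound at the concentration tested, a lower number a stronger effect), compound 1 gives the lowest of the three numbers. Its nearest neighbour is compound 3, reached by a number 0.3 percentage points higher from compound 1 to compound 3 (within the scatter); the furthest is compound 2, reached by a number 7.1 percentage points higher from compound 1 to compound 2 (within the scatter). Between the other two lies a number 6.8 percentage points lower from compound 2 to compound 3 (within the scatter). All three steps stay within the usual scatter, so the three compounds cannot be told apart on these numbers.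

Compound 4 `CCCS(=O)(=O)Nc1ccc(F)c(C(=O)c2n[nH]c3ncc(-c4ccc(S(C)(=O)=O)cc4)cc23)c1F` is not yet measured. It differs from compound 1 by 4-(methylsulfonyl)phenyl in place of 2-methoxyphenyl on an aromatic carbon. For the measured compounds named here, the steps that bear on this change are the three just given, each of which alters the group on the same aromatic carbon and each of which stays within the scatter. On that basis no step beyond the scatter is expected from compound 1 to compound 4, though the aryl group entering here is larger and carries a different substituent than any of the measured variants, so the range is kept wide. Compound 4 is therefore estimated at 5%, with a range from 0.5% to 25%, which means an expected step of a number 3.1 percentage points higher from compound 1 to compound 4 (within the scatter).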

Compound 4, a percentage reported as activity, at one concentration (the size of the read-out at that concentration, not a potency): 1.5%
The estimate for compound 4 lay 3.5 percentage points above the measured number; measured number inside the range.
By their numbers in this assay, from the lowest: compounds 4, 1, 3 and 2 (each within the scatter of the next).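

At the aromatic carbon two atoms from the ring nitrogen, this assay shows a number 0.4 percentage points lower from compound 1 to compound 4 (within the scatter) when 4-(methylsulfonyl)phenyl replaces 2-methoxyphenyl. The comparisons with the two hydroxyphenyl compounds agree, with a number 0.7 percentage points lower from compound 3 to compound 4 (within the scatter) and a number 7.5 percentage points lower from compound 2 to compound 4 (within the scatter), so this change brings no step beyond the scatter even though the entering group has more heavy atoms, adds sulfur and counts 2 hydrogen-bond acceptors, which the earlier variation of hydroxy and methoxy groups on the phenyl ring did not test. No available evidence bears on the reason for this result.

Going by these compounds, the four compounds carry only substituted phenyl groups at this carbon, so it remains open whether a phenyl ring bearing an amine or a carboxylic acid, a pyridine ring, or a plain methyl group in place of the ring would give a step beyond the scatter. Each compound is also read at a single concentration, which leaves open whether compounds that cannot be told apart here would also match in potency.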